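Benzyloxy in place of carboxyphenoxy on the shared core

A few compounds are considered here, and "the series" means these few. Any claim that something is new, unique, unknown or untested is made for them only; others in the source may bear on it.

Two compounds of this series have been run in an assay on isolated protein for agonist activity at Bile acid receptor (Homo sapiens), read by AlphaScreen, with a stated time of 30 min; a lower number here means that less compound is needed, a higher number that more compound is needed for the effect. Compound 1 `Cc1ccccc1-n1nc(C)c2c1NC(=O)[C@H](C)S[C@@H]2c1ccc(-c2cc3ccccc3o2)cc1` gives 1500 nM in this assay. Compound 2 `Cc1ccccc1-n1nc(C)c2c1NC(=O)[C@H](C)S[C@@H]2c1ccc(Oc2cccc(C(=O)O)c2)cc1` is reported in this assay as "not active" (no number reported), so no single number places compound 2; it stands only as the weaker of the two against compound 1 with 1500 nM. Compound 3 `Cc1ccccc1-n1nc(C)c2c1NC(=O)[C@H](C)S[C@@H]2c1ccc(OCc2ccccc2)cc1` has not yet been measured. Its difference from compound 2 is benzyl in place of 3-carboxyphenyl on an oxygen on an aromatic ring. Among the measured compounds shown here, no step between measured compounds is available, so the expectation rests on compound 1 and compound 2 alone. In this assay, for the measured compounds named here, a shift from compound 2 to compound 3 toward less compound needed is expected, of a size beyond the scatter, since compound 2 shows no activity while compound 1, the only other member with a number, gives 1500 nM. For compound 3 the estimate in this assay is 3000 nM, with a range from 700 nM to 15000 nM.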

Compound 3, half-maximal effective concentration: "not active" (no number reported)
For compound 3 the study gives words and no number; there is nothing to compare the estimate with.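

Compound 2 and compound 3 are both reported as not active in this assay, so no step can be read between them. The compounds shown leave open how 3-carboxyphenoxy and benzyloxy compare on the shared core. Nothing at hand bears on this result.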